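Thiophene for furan on two related nucleoside cores

A few compounds are considered here, and "the series" means these few. Any claim that something is new, unique, unknown or untested is made for them only; others in the source may bear on it.

Compounds measured in a functional assay on HepG2 cells (Homo sapiens) for antiproliferative activity, read by XTT assay, with a stated time of 72 h; a higher number here means a weaker inhibitor, a lower number a stronger inhibitor:
compound 1, `Cc1nc(N)c2c(-c3cccs3)cn([C@@H]3O[C@H](CO)[C@@H](O)[C@H]3O)c2n1`, which gives > 20000 nM, a limit of the assay;
compound 2, `Cc1nc(N)c2c(-c3ccco3)cn([C@@H]3O[C@H](CO)[C@@H](O)[C@H]3O)c2n1`, which gives > 20000 nM, again a limit;
compound 3, `Nc1nc2c(c(-c3ccco3)cn2[C@@H]2O[C@H](CO)[C@@H](O)[C@H]2O)c(=O)[nH]1`, which gives > 20000 nM, also a limit.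

Compound 1 and compound 2 share one core and differ only by thiophen-2-yl in place of furan-2-yl on an aromatic carbon. The step that the two limits leave unreadable from compound 2 to compound 1 cannot be sized, because of the limit of > 20000 nM in this assay, at which 3 of the 3 values shown sit. Compound 3 carries a different core; how the core of compound 3 differs from that of compound 2 is not broken down here.

Compound 4, `Nc1nc2c(c(-c3cccs3)cn2[C@@H]2O[C@H](CO)[C@@H](O)[C@H]2O)c(=O)[nH]1`, is not yet measured. It differs from compound 3 by thiophen-2-yl in place of furan-2-yl on an aromatic carbon, the same change that turns compound 2 into compound 1, at the same place.

Among the compounds with values here, with no readable step to lean on, the expectation rests on the single fact that compound 2 and compound 1 both sit at the limit. The step that the limit leaves unreadable from compound 3 to compound 4 is expected to be flat, with the value most likely again a limit rather than a number. Compound 4 is therefore estimated at 30000 nM in this assay, within 12000 nM to 100000 nM.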

Compound 4, half-maximal inhibitory concentration: > 20000 nM
Compound 4 ended at the assay's limit (the forecaster's own chance of this, stated with the estimate: 85%); the middle value lies beyond the limit too.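

In this assay compound 4 gives > 20000 nM, a limit of the assay and not a number. Within the data shown here, no step from compound 3 to compound 4 can be read, any more than the one from compound 2 to compound 1: the limit of > 20000 nM in this assay, at which 4 of the 4 values shown sit. The compounds shown leave open whether thiophen-2-yl in place of furan-2-yl makes any difference on either core.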